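Removing a Chloro Group from a Urea Aryl Ring

The compounds below may be only part of what the source reports. "The series", "measured", "known", "first", "only" and "open" are said of these compounds alone.

Compound 2 `COc1cc(Cl)cc(-c2nn(-c3cccc(NC(=O)Nc4ccc(Cl)c(C(F)(F)F)c4)c3)cc2-c2ccncc2)c1` gives -85% in a functional assay on SK-MEL-2 cells (Homo sapiens) for inhibition, read by sulforhodamine B assay, with a stated time of 48 h, tested at 100 uM; on this read-out lower numbers stand for a stronger effect and higher numbers for a weaker effect at the one concentration tested. Compound 1 `O=C(Nc1cccc(-n2cc(-c3ccncc3)c(-c3cc(O)cc(Cl)c3)n2)c1)Nc1ccc(Cl)c(C(F)(F)F)c1` carries hydrogen where compound 2 carries methyl on an oxygen; in this assay compound 1 gives -88%. The step of a number 3 percentage points higher from compound 1 to compound 2 (within the scatter) shows the two numbers sit within the usual scatter of each other. Compound 3 `COc1cc(Cl)cc(-c2nn(-c3cccc(NC(=O)Nc4cccc(C(F)(F)F)c4)c3)cc2-c2ccncc2)c1` differs from compound 2 by hydrogen in place of chloro on an aromatic carbon. Within the data shown here, no measured step touches this part of the molecule, so the only known step says nothing direct about it. Compound 3 is therefore estimated at -70%, within -95% to -30%, an expected step of a number 15 percentage points higher from compound 2 to compound 3 (beyond the scatter) that allows for some loss of effect.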

Compound 3, a percentage reported as activity, at one concentration (the size of the read-out at that concentration, not a potency): -68%
The estimate for compound 3 lay 2 percentage points below the measured number; the measured number falls inside the stated range.
By their numbers in this assay, from the lowest: compounds 1 and 2 (each within the scatter of the next); then compound 3.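

Replacing chloro with hydrogen on the 4-chloro-3-(trifluoromethyl)phenyl ring gives a number 17 percentage points higher from compound 2 to compound 3 (beyond the scatter) in this assay, so the effect weakens but remains substantial. Unlike the change on oxygen between compound 1 and compound 2, this change produces a step beyond the scatter, showing that the read-out responds to the group at this position. Nothing here explains why the effect weakens. From the compounds shown here alone, whether fluoro, methyl or an amine at this position would match compound 2 or fall nearer compound 3 remains open.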